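Trimming a Chain Carbon in a Series That Shows No Effect

A few compounds are considered here, and "the series" means these few. Any claim that something is new, unique, unknown or untested is made for them only; others in the source may bear on it.

Compound 3 `CCC(C(=O)N1CCN(c2cccc(C)c2)CC1)N1C(=O)CCC1=O` gives 0% in a functional assay on the whole organism (strain Swiss) with Mus musculus as the target, in the maximal electroshock model, with a stated time of 1 h, at a dose of 100 mg/kg by the intraperitoneal route (a higher number here means a stronger effect of the compound at the dose given, a lower number a weaker effect), level with compound 1 `CC(C(=O)N1CCN(c2ccc(F)cc2)CC1)N1C(=O)CCC1=O`, which gives 0%, and with compound 2 `CC(C(=O)N1CCN(c2ccccc2F)CC1)N1C(=O)CCC1=O`, which gives 0%. For the measured compounds named here, the only measured step, no change at the digits printed from compound 1 to compound 2 (within the scatter), moves a fluorine on the aryl ring and leaves the read-out where it was. Compound 4 `Cc1cccc(N2CCN(C(=O)C(C)N3C(=O)CCC3=O)CC2)c1` differs from compound 3 by hydrogen in place of methyl on a saturated chain carbon, two bonds along the chain from an amide-type nitrogen in a ring and a carbonyl carbon. Going by the values given here, no measured step touches this part of the molecule, so nothing shows directly how shortening the chain would act; what is known is that three compounds with varied side groups all sit at the same read-out. Compound 4 is therefore expected to stay put, with no change at the digits printed from compound 3 to compound 4 (within the scatter) amounting to essentially nothing. In this assay compound 4 is estimated at 0%, within 0% to 10%.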

Compound 4, a percentage reported as activity, at one dose (the size of the read-out at that dose, not a potency): 0%
Estimate against measurement, compound 4: no gap at the digits printed; measured number inside the range.
By their numbers in this assay, from the lowest: compounds 1, 2, 3 and 4 (each within the scatter of the next).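

Hydrogen in place of methyl on this chain carbon gives no change at the digits printed from compound 3 to compound 4 (within the scatter) in this assay and is the first direct look at this position: ethyl to methyl leaves the read-out where it was. With the shorter chain, 3-methylphenyl in place of 2-fluorophenyl gives no change at the digits printed from compound 2 to compound 4 (within the scatter) and 3-methylphenyl in place of 4-fluorophenyl gives no change at the digits printed from compound 1 to compound 4 (within the scatter) as well. No evidence on this result is available. Still open, on these data alone, is whether a longer chain or a phenyl group on this carbon would give any effect. Level read-outs alone cannot show whether this position matters.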